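The source may report more compounds than this note shows. Statements on the series, on what has been measured and on what is new or still open speak of the compounds shown alone.

Measured so far:
compound 1, `OC(CCn1nc2c(Br)c(Br)c(Br)c(Br)c2n1)c1ccccc1`: 28%
compound 2, `CC(O)CCn1nc2c(Br)c(Br)c(Br)c(Br)c2n1`: 90%

In a functional assay on MCF7 cells (Homo sapiens) for antiproliferative activity, read by MTT assay, with a stated time of 24 h, tested at 50 uM (a higher number here means a weaker effect of the compound at the concentration tested, a lower number a stronger effect), compound 2 gives the highest of the two numbers. Going by the values given here, its only neighbour is compound 1, and the step between them, a number 62 percentage points higher from compound 1 to compound 2 (beyond the scatter), is the one measured step available. Compound 3, `OC(CCn1nc2c(Br)c(Br)c(Br)c(Br)c2n1)c1ccc(Cl)cc1`, differs from compound 2 by 4-chlorophenyl in place of methyl on a saturated chain carbon bound to an oxygen on a saturated carbon and a saturated chain carbon. This change runs opposite to the measured step: there methyl replaced phenyl on the same saturated chain carbon bound to an oxygen and the number rose by a large margin, whereas here an aromatic ring returns to that position, now carrying a chlorine. Because a number 62 percentage points higher from compound 1 to compound 2 (beyond the scatter) was large, a large step downward in this assay is expected for compound 3, with the added chlorine an unknown on top of it. Compound 3 is therefore expected to give about 30% in this assay, within 12% to 55%, an estimated step of a number 60 percentage points lower from compound 2 to compound 3 (beyond the scatter).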

Compound 3, a percentage reported as activity, at one concentration (the size of the read-out at that concentration, not a potency): 19%
For compound 3 the middle estimate is 11 percentage points above the measured one; low and high end bracket the measured number.
By their numbers in this assay, from the lowest: compounds 3 and 1 (each within the scatter of the next); then compound 2.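

With 4-chlorophenyl in place of methyl on the saturated chain carbon bound to an oxygen, the result in this assay is a number 71 percentage points lower from compound 2 to compound 3 (beyond the scatter) and so shows that the large difference between methyl and phenyl at this position also appears with a second aromatic group. Chloro in place of hydrogen on an aromatic carbon gives a number 9 percentage points lower from compound 1 to compound 3 (within the scatter) and so does not separate compound 3 from compound 1. Among these compounds, the chlorine on the ring adds nothing that can be told from the scatter, while the aromatic ring in place of methyl goes with the large step.

The compounds shown leave open how a methoxy group or a nitrile on that ring, a longer chain, or an amine in place of the oxygen would read in this assay at this position. Nothing available here explains the effect of the aromatic ring.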